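The source may hold more compounds than are shown below. What is called first, only, known or untested is meant among the compounds shown, and "the series" means these compounds.

Compound 2 `Cc1c2c(n3c1CCN(C)C[C@@H](C)[C@H](C)Nc1cc-3ccc1C(N)=O)CC(C)(C)CC2=O` and compound 1 `Cc1c2c(n3c1CCCN[C@@H](C)[C@H](C)Nc1cc-3ccc1C(N)=O)CC(C)(C)CC2=O` share one core and differ only in the ring amine, yet in a functional assay on HCT-116 cells (Homo sapiens) for antiproliferative activity (a higher number here means a weaker inhibitor, a lower number a stronger inhibitor), compound 2 gives 27 nM and compound 1 gives 29 nM, a gap that lies within the scatter. Compound 2 thus holds the lower of the two numbers without being separated from compound 1. Compound 3 `Cc1c2c(n3c1CCN(C(=O)C1(N)CC1)C[C@@H](C)[C@H](C)Nc1cc-3ccc1C(N)=O)CC(C)(C)CC2=O` carries the change ((1-aminocyclopropyl)carbonyl in place of methyl on an amine nitrogen in a ring). For the measured compounds named here, no measured pair maps this step, and the closeness of the two known values suggests the amine tolerates substitution, so compound 3 is expected to shift by a 1.7-fold higher number from compound 2 to compound 3 (0.22 log units; within the scatter) at most modestly, giving an estimated 45 nM with a range from 12 nM to 170 nM.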

Compound 3, half-maximal inhibitory concentration: 81 nM
The estimate for compound 3 lay 1.8-fold (0.26 log units) below the measured number, within the range that was stated.
By their numbers in this assay, from the lowest: compounds 2 and 1 (each within the scatter of the next); then compound 3.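

In this assay, the amine nitrogen in the ring proves sensitive to what it carries: (1-aminocyclopropyl)carbonyl in place of methyl gives a 3.0-fold higher number from compound 2 to compound 3 (0.48 log units; beyond the scatter) and so a modest weakening, though compound 3 still stands at 81 nM in the same read-out. For the compounds shown here, the earlier compounds offered no step at this position, so this is the first sign that a change here can move the number beyond the scatter. No measurement at hand accounts for the shift. Going by these compounds, it remains open whether the carbonyl, the cyclopropane ring or the free amine drives this step, and how a plain acetyl or an aminoacetyl group on this nitrogen would compare.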